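Methyl removal on the aromatic ring: estimate for compound 4

A few compounds are considered here, and "the series" means these few. Any claim that something is new, unique, unknown or untested is made for them only; others in the source may bear on it.

Compound 2 `Cc1cccc(/C(N)=N/NC(=S)N2CCCCCC2)n1` gives 1000 nM in a functional assay on HeLa cells (Homo sapiens) for cytotoxicity, read by MTT assay, with a stated time of 72 h; a lower number here means a stronger inhibitor, a higher number a weaker inhibitor. Compound 1 `N/C(=N\NC(=S)N1CCCCCC1)c1ccccn1` gives 6000 nM in this assay. The change from compound 2 to compound 1 is hydrogen in place of methyl on an aromatic carbon and gave a 6.0-fold higher number from compound 2 to compound 1 (0.78 log units; beyond the scatter). Compound 3 `Cc1cccc(/C(N)=N/NC(=S)N2CCCC2)n1` carries a different core; how the two cores differ is not broken down here. In this assay compound 3 gives 2700 nM. Going by the values given here, compound 4 `N/C(=N\NC(=S)N1CCCC1)c1ccccn1` has not been measured; it differs from compound 3 by hydrogen in place of methyl on an aromatic carbon, the same change as the one made from compound 2 to compound 1, at a place described in the same words. In this assay compound 4 is expected to give 15000 nM, with a range from 6000 nM to 40000 nM. Among the compounds with values here, the expected step of a 5.6-fold higher number from compound 3 to compound 4 (0.74 log units; beyond the scatter) is set close to the earlier step because of a 6.0-fold higher number from compound 2 to compound 1 (0.78 log units; beyond the scatter), with only one prior example to rest on.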

Compound 4, half-maximal inhibitory concentration: 6200 nM
For compound 4 the middle estimate is 2.4-fold (0.38 log units) above the measured one, within the range that was stated.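

In this assay, hydrogen in place of methyl again raises the number on the second core, giving a 2.3-fold higher number from compound 3 to compound 4 (0.36 log units; beyond the scatter), so the direction of the change carries across the two cores shown. The size of the step does not separate between these cores: the same change on two cores in this assay, a 6.0-fold higher number (0.78 log units; beyond the scatter) from compound 2 to compound 1 and a 2.3-fold higher number (0.36 log units; beyond the scatter) from compound 3 to compound 4, 2.6-fold (0.42 log units) apart, within the scatter of two such steps. Going by these compounds alone, this rests on only two pairs of compounds, so it gives no reason for the step and does not show that the change would carry to any other core.

Open, as far as these compounds go, is whether ethyl, methoxy or chlorine on this aromatic carbon would behave as methyl does. Also open, from the compounds shown here alone, is whether the step holds on a core carrying an open-chain dimethylamino group.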